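A few compounds are considered here, and "the series" means these few. Any claim that something is new, unique, unknown or untested is made for them only; others in the source may bear on it.

Among the measured compounds shown here, in an ADME assay on a cell-free system (plasma, Homo sapiens) (on this read-out higher numbers stand for a larger free fraction and lower numbers for a smaller free fraction), compound 2 (`CC(C)c1ccc(S(C)(=O)=O)cc1C#Cc1cc(Cl)ccc1OCC(=O)O`) gives 0.003, the only number available so far, whereas compound 1 (`CC(C)S(=O)(=O)c1ccc(Cl)c(C#Cc2cc(Cl)ccc2OCC(=O)O)c1`) is reported as "not determined" (no result reported). Compound 3 (`CS(=O)(=O)c1ccc(Cl)c(C#Cc2cc(Cl)ccc2OCC(=O)O)c1`) differs from compound 2 by a single change, chloro in place of isopropyl on an aromatic carbon. For the measured compounds named here, no measured pair shows what such a swap does here, so this is a cautious judgement. A modest rise in the free fraction is expected, about the size of the usual scatter between repeats, with an estimated 2.0-fold higher number from compound 2 to compound 3 (0.30 log units; within the scatter). The expected value for compound 3 is 0.006, within an estimated range of 0.003 to 0.012.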

Compound 3, unbound fraction: 0.007
Compound 3: middle estimate off by 1.2-fold (0.07 log units), on the low side; the range from low to high includes it.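

Among the compounds shown here, this step gives the first reading of how the group on this aromatic carbon, para to a methylsulfonyl group, affects this assay: chloro in place of isopropyl gives a 2.3-fold higher number from compound 2 to compound 3 (0.37 log units; beyond the scatter). Swapping isopropyl for the smaller chloro therefore goes with a modest but real rise in the free fraction. Nothing available explains this shift.

A single step cannot show whether size alone tracks this read-out here. From the compounds shown here alone, how a methoxy group, a fluoro group or an amine at this position would compare remains open.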